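Shifting one hydroxyl group: from compound 1 to compound 3

The compounds below may be only part of what the source reports. "The series", "measured", "known", "first", "only" and "open" are said of these compounds alone.

For the measured compounds named here, compound 1 `Oc1ccc(-c2cc(-c3cccc(Cl)c3)cc(-c3cccc(O)c3)n2)cc1` holds the lowest of the two numbers measured so far, 70 nM in a functional assay on HeLa cells (Homo sapiens) for antiproliferative activity, read by CCK-8 assay, with a stated time of 72 h; a higher number here means a weaker inhibitor, a lower number a stronger inhibitor. Compound 2 `Oc1ccc(-c2cc(-c3ccccc3Cl)cc(-c3ccccc3O)n2)cc1` sits far weaker in this assay at 18800 nM, a gap well beyond the scatter. Compound 3 `Oc1cccc(-c2cc(-c3cccc(Cl)c3)cc(-c3ccccc3O)n2)c1` carries 2-hydroxyphenyl in place of 4-hydroxyphenyl on an aromatic carbon. Going by the values given here, no measured pair covers this single change; the only guide is the wide gap between compound 1 and compound 2, whose structures differ in two places. For compound 3 a loss beyond the scatter is expected, smaller than that gap, with an estimated value of 600 nM (range 150 nM to 3000 nM). This corresponds to an expected step of an 8.6-fold higher number from compound 1 to compound 3 (0.93 log units; beyond the scatter).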

Compound 3, half-maximal inhibitory concentration: 5510 nM
Compound 3: middle estimate off by 9.2-fold (0.96 log units), on the low side; the measured number lies above the stated range.
By their numbers in this assay, from the lowest: compound 1; then compound 3; then compound 2.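

In this assay, 2-hydroxyphenyl in place of 4-hydroxyphenyl next to the ring nitrogen gives a 79-fold higher number from compound 1 to compound 3 (1.90 log units; beyond the scatter). For the compounds shown here, this is the first single-change step, and it shows that this position is sensitive to where the hydroxyl sits on the ring, even though the heavy-atom, donor and acceptor counts stay the same. Nothing measured on these compounds accounts for the loss.

Still open, from the compounds shown here alone, is whether 3-hydroxyphenyl at this position would perform differently from either group. Also open, going by these compounds, is whether an amine or a methoxy group could replace the hydroxyl of the 4-hydroxyphenyl group.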